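A few compounds are considered here, and "the series" means these few. Any claim that something is new, unique, unknown or untested is made for them only; others in the source may bear on it.

Compound 3 `COc1ccc2ncc(S(=O)(=O)c3ccc(OC)c(Cl)c3)c(N3CCC(C)CC3)c2c1` stands lowest of the three measured compounds in an assay on isolated protein for displacement of a labelled ligand from metabotropic glutamate receptor 5 (Homo sapiens), with a stated time of 60 min, tested at 1 uM (on this read-out lower numbers stand for less inhibition and higher numbers for more inhibition at the one concentration tested (going by the name of the read-out)), where compound 3 gives 21%. Compound 1 `CC1CCN(c2c(S(=O)(=O)c3ccc(Cl)c(Cl)c3)cnc3ccc(F)cc23)CC1` gives 91% in this assay, and compound 2 `Cc1cc(C)cc(S(=O)(=O)c2cnc3ccc(F)cc3c2N2CCC(C)CC2)c1` gives 83% in this assay; both lie above compound 3 by gaps beyond the scatter. Compound 4 `COc1ccc(S(=O)(=O)c2cnc3ccc(F)cc3c2N2CCC(C)CC2)cc1Cl` differs from compound 3 by fluoro in place of methoxy on an aromatic carbon. Within the data shown here, no measured pair changes this position on the core. Among the measured compounds shown here, the one measured step, a number 8 percentage points lower from compound 1 to compound 2 (within the scatter), alters only the aryl on the sulfonyl sulfur and stays within the scatter, so the values of compounds 1 and 2 suggest that the aryl on the sulfonyl sulfur does little, which leaves the methoxy on the core as the remaining difference between compound 3 and the two compounds with the higher numbers. Compound 4 carries the fluoro on the core shared by compounds 1 and 2, so an upward step is expected, estimated as a number 49 percentage points higher from compound 3 to compound 4 (beyond the scatter). Compound 4 is therefore estimated at 70% in this assay, within a range from 35% to 95%; the untested aryl on the sulfonyl sulfur keeps this range wide.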

Compound 4, a percentage reported as inhibition, at one concentration (the size of the read-out at that concentration, not a potency): 82%
Beside the measured number, compound 4's estimate is 12 percentage points below it; measured number inside the range.
By their numbers in this assay, from the lowest: compound 3; then compounds 4, 2 and 1 (each within the scatter of the next).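

In this assay, among these compounds, fluoro in place of methoxy on the shared core gives a number 61 percentage points higher from compound 3 to compound 4 (beyond the scatter), so this is the first measured change at this position, and it is a large one. With the fluoro kept, the aryl on the sulfonyl sulfur again matters little, with a number 1 percentage points lower from compound 2 to compound 4 (within the scatter) and a number 9 percentage points lower from compound 1 to compound 4 (within the scatter), so the 3-chloro-4-methoxyphenyl that compound 3 also carries does not by itself go with a low number. Nothing available explains why this swap on the core has so large an effect.

Going by these compounds, only fluoro and methoxy are seen at this position, so it remains open how a nitrile, an amine or a longer alkoxy chain would compare there. On these data alone, with a single concentration per compound, the potencies behind these numbers also remain open.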